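The compounds below may be only part of what the source reports. "The series", "measured", "known", "first", "only" and "open" are said of these compounds alone.

Three compounds share one core and differ in a halogen on an aromatic ring. Compound 1 `CCC(=O)N(c1cccc(F)c1)C1CCCC1N(C)C` carries fluoro, compound 3 `CCC(=O)N(c1cccc(Br)c1)C1CCCC1N(C)C` carries bromo in the same place, and compound 2 `CCC(=O)N(c1ccc(F)cc1)C1CCCC1N(C)C` carries fluoro on a core whose difference from that of compound 1 is not broken down here. In a functional assay on the whole organism for positive allosteric modulation, with Mus musculus as the target (on this read-out lower numbers stand for an effect already at smaller amounts and higher numbers for an effect only at larger amounts of compound), compound 1 gives 5 mg/kg, and compound 3 gives 2 mg/kg. The change from compound 1 to compound 3 is bromo in place of fluoro on an aromatic carbon, and it brought a 2.5-fold lower number from compound 1 to compound 3 (0.40 log units; beyond the scatter). For compound 2 only a limit of the assay is known: in this assay compound 2 gives > 50 mg/kg, which is the limit of > 50 mg/kg in this assay, at which 1 of the 3 values shown sits. Compound 4 `CCC(=O)N(c1ccc(Br)cc1)C1CCCC1N(C)C` is not yet measured; its change from compound 2 is bromo in place of fluoro on an aromatic carbon, the same kind of change as before, though here the halogen sits para to a large group rather than meta to a large group. A step of about an at least 1.6-fold lower number from compound 2 to compound 4 (0.22 log units; that floor lies within the scatter) is expected from compound 2 to compound 4, resting on a 2.5-fold lower number from compound 1 to compound 3 (0.40 log units; beyond the scatter). The starting value for compound 2 is a limit, which leaves the estimate for compound 4 uncertain. Compound 4 is estimated at 30 mg/kg, with a range from 10 mg/kg to 100 mg/kg.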

Compound 4, dose for half-maximal effect: > 50 mg/kg
Compound 4: only a limit was reported; the forecaster's own chance of this, stated with the estimate: 50%; middle value at least 1.6-fold (0.22 log units) away from the limit.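

In this assay, compound 2 and compound 4 each give only a limit and not a number, so the step between them cannot be read: the limit of > 50 mg/kg in this assay, at which 2 of the 4 values shown sit. The compounds shown leave open how much bromo in place of fluoro changes the read-out when the halogen sits para to a large group.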